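Methyl on the amide nitrogen: compound 3 to compound 4

The source may report more compounds than this note shows. Statements on the series, on what has been measured and on what is new or still open speak of the compounds shown alone.

compound 1 `COc1cc(CN(C)C(=O)c2cc(Cl)c(O)cc2O)c(Cl)c(OC)c1OC` gives 2400 nM
compound 2 `COc1cc(CN(C)C(=O)c2cc(Cl)c(O)cc2O)cc(OC)c1OC` gives 30100 nM
compound 3 `O=C(NCc1ccccc1)c1cc(Cl)c(O)cc1O` gives "not active" (no number reported)

Going by the values given here, in a functional assay on SK-BR-3 cells (Homo sapiens) for antiproliferative activity, with a stated time of 72 h (on this read-out higher numbers stand for weaker inhibition of growth and lower numbers for stronger inhibition of growth), compound 3 is reported as "not active" (no number reported) with no number, so no step can be counted from it. The change to compound 4 `CN(Cc1ccccc1)C(=O)c1cc(Cl)c(O)cc1O` is methyl in place of hydrogen on an amide-type nitrogen. Among the compounds with values here, the only measured step is a 13-fold higher number from compound 1 to compound 2 (1.10 log units; beyond the scatter) and it is large, but it is hydrogen in place of chloro on an aromatic carbon and does not test this change. Within the data shown here, no size of step can be derived. Compound 2 carries that methyl and gives 30100 nM so weak inhibition of growth is expected at best. Compound 4 is estimated at 30000 nM (expected range 8000 nM to 100000 nM).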

Compound 4, concentration for 50% growth inhibition: 18300 nM
Beside the measured number, compound 4's estimate is 1.6-fold (0.21 log units) above it; the range from low to high includes it.
By their numbers in this assay, from the lowest: compound 1; then compounds 4 and 2 (each within the scatter of the next).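

In this assay compound 3 carries no number and compound 4 gives 18300 nM so no new step can be read between them. Going by these compounds, the size of any change from methyl in place of hydrogen on the amide-type nitrogen stays open. No evidence bears on this result.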